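The source may hold more compounds than are shown below. What is called first, only, known or untested is meant among the compounds shown, and "the series" means these compounds.

Measured so far in a functional assay on Huh-7 cells (Homo sapiens) for cytotoxicity, with a stated time of 48 h; on this read-out lower numbers stand for stronger inhibition and higher numbers for weaker inhibition:
compound 1 `COc1cc(OC)c(C(=O)/C=C/c2ccccc2SC)c(OC)c1` gives 14100 nM
compound 2 `COc1cccc(/C=C/C(=O)c2c(OC)cc(OC)cc2OC)c1` gives 8900 nM

Within the data shown here, compound 2 cannot be told apart from compound 1 on these numbers, with a 1.6-fold lower number from compound 1 to compound 2 (0.20 log units; within the scatter) as the only measured step. Compound 3 `COc1cccc(/C=C/C(=O)c2c(O)cc(OC)cc2OC)c1` differs from compound 2 by one change (hydrogen in place of methyl on an oxygen on an aromatic ring), hydrogen in place of methyl on an oxygen on an aromatic ring. Among the measured compounds shown here, that measured step lies at another place, and no measured step covers this change, so nothing beyond the scatter is expected in either direction. The step expected in this assay is a 1.3-fold lower number from compound 2 to compound 3 (0.10 log units; within the scatter) and no more. Compound 3 is expected at 7000 nM with an estimated range of 2500 nM to 20000 nM in this read-out.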

Compound 3, half-maximal inhibitory concentration: 15000 nM
The estimate for compound 3 lay 2.1-fold (0.33 log units) below the measured number; the range from low to high includes it.
By their numbers in this assay, from the lowest: compounds 2, 1 and 3 (each within the scatter of the next).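

The first change shown on this oxygen, methoxy to hydroxy, gives in this assay a 1.7-fold higher number from compound 2 to compound 3 (0.23 log units; within the scatter) and leaves the two compounds indistinguishable on this read-out. At this place, then, the methyl on the oxygen can give way to hydrogen without a change beyond the scatter. No evidence on the cause of this result is available. The compounds shown leave open whether a longer chain on this oxygen, or an amine in place of the methoxy group, would separate from compound 2 beyond the scatter.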